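Phenyl Replacing Substituted Aryl on the Ring Nitrogen

A few compounds are considered here, and "the series" means these few. Any claim that something is new, unique, unknown or untested is made for them only; others in the source may bear on it.

Measured in a functional assay on 143B cells (Homo sapiens) for inhibition, read by CCK-8 assay, with a stated time of 72 h, tested at 1 uM; a higher number here means more inhibition at the concentration tested (going by the name of the read-out), a lower number less inhibition:
compound 1 `COc1ccc(C)cc1N1C(=O)CSC1c1cccc(C(=O)NCCCCc2ccccc2)c1`: 29%
compound 2 `COc1ccccc1N1C(=O)CSC1C(=O)NCCCCc1ccccc1`: 4%

Among the compounds with values here, compound 1 stands highest of the two numbers; compound 2 lies a step below it that is beyond the scatter, but the two structures differ in more than one place, so no single-change step is available. Compound 3 `O=C(NCCCCc1ccccc1)c1cccc(C2SCC(=O)N2c2ccccc2)c1` is not yet measured. It differs from compound 1 by phenyl in place of 2-methoxy-5-methylphenyl on an amide-type nitrogen in a ring. Within the data shown here, no measured pair isolates this kind of change. In this assay the expected step is a number 9 percentage points lower from compound 1 to compound 3 (within the scatter), a small decrease of about the size of the scatter. Compound 3 is estimated at 20%, with a range from 5% to 35%.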

Compound 3, a percentage reported as inhibition, at one concentration (the size of the read-out at that concentration, not a potency): 60%
The estimate for compound 3 lay 40 percentage points below the measured number, and the stated range ends below it.
By their numbers in this assay, from the lowest: compound 2; then compound 1; then compound 3.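

Replacing 2-methoxy-5-methylphenyl with phenyl on the amide-type nitrogen in a ring gives a number 31 percentage points higher from compound 1 to compound 3 (beyond the scatter) in this assay. The methoxy and methyl groups are therefore not required for inhibition in this series, and at this position the unsubstituted phenyl reads higher. Nothing available accounts for the gain.

Methoxy and methyl leave together in this step, and their separate contributions remain open. Also open, as far as these compounds go, is how a pyridyl ring, or a fluorine or an amine on the phenyl, would read at this position.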